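Propyl to butyl on the shared core

The source may report more compounds than this note shows. Statements on the series, on what has been measured and on what is new or still open speak of the compounds shown alone.

Measured so far in a functional assay on the whole organism (strain Hartley) for inhibition, with Cavia porcellus as the target, with stated times of 15 min and 2 min (on this read-out lower numbers stand for an effect already at smaller amounts and higher numbers for an effect only at larger amounts of compound), are these compounds
compound 1 `CCCCC1([C@@H](O)/C=C/C2[C@H](O)CC(=O)[C@@H]2CCCCCCC(=O)O)CCC1` gives 0.0439 mg/kg
compound 2 `CCCCC1([C@H](O)/C=C/C2[C@H](O)CC(=O)[C@@H]2C/C=C\CCCC(=O)O)CCC1` gives 0.00251 mg/kg
compound 3 `CCCC1([C@@H](O)/C=C/C2[C@H](O)CC(=O)[C@@H]2C/C=C\CCCC(=O)O)CCC1` gives 0.265 mg/kg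

Compound 3 has the highest number of the three, and it lies beyond the scatter from both compound 1 and compound 2. The next candidate is compound 4 `CCCCC1([C@@H](O)/C=C/C2[C@H](O)CC(=O)[C@@H]2C/C=C\CCCC(=O)O)CCC1` and its change from compound 3 is methyl in place of hydrogen on a saturated chain carbon, three bonds along the chain from a saturated ring carbon. This turns propyl into butyl.

Going by the values given here, no measured pair isolates this change, so the expectation rests on indirect evidence. Compound 1 (at 0.0439 mg/kg) and compound 2 (at 0.00251 mg/kg) both carry the butyl chain and both sit below compound 3 (at 0.265 mg/kg). These two butyl values lie far apart, which argues for a wide range. A lower number is expected in this assay and the estimated step, beyond the scatter, is an 8.8-fold lower number from compound 3 to compound 4 (0.95 log units; beyond the scatter) in this reading. For compound 4 the expected value is 0.03 mg/kg with an estimated range from 0.006 mg/kg to 0.15 mg/kg on this basis.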

Compound 4, dose for half-maximal effect: 0.305 mg/kg
Estimate against measurement, compound 4: 10-fold (1.01 log units) below; measured number above the stated range.
By their numbers in this assay, from the lowest: compound 2; then compound 1; then compounds 3 and 4 (each within the scatter of the next).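

In this assay, methyl in place of hydrogen at this place, which turns propyl into butyl, gives a 1.2-fold higher number from compound 3 to compound 4 (0.06 log units; within the scatter), so with this configuration the butyl chain alone does not set compound 4 apart from compound 3. The steps beyond the scatter lie elsewhere: the stereocentre at a saturated chain carbon, drawn R in compound 2 and S in compound 4, gives a 120-fold higher number from compound 2 to compound 4 (2.08 log units; beyond the scatter), and 5-carboxypent-1-en-1-yl in place of 5-carboxypentyl gives a 6.9-fold higher number from compound 1 to compound 4 (0.84 log units; beyond the scatter). The stereocentre step carries one reservation on how the structures are drawn: the fact that one of compounds 2 and 4 is drawn with a defined configuration and the other without, at the place where they differ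

The compounds shown leave open whether propyl to butyl gives a step within the scatter in the configuration drawn for compound 2. They also leave open how a longer chain such as hexyl, or a terminal hydroxyl on the chain, would read at this place.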